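This account rests on a few compounds, and the source may have more. Where it says the series, first, only, none or still open, it means among the compounds named here.

Compound 1 `c1ccc(Cc2ccc3c(NCCCNCc4ccco4)ccnc3c2)cc1`: 9.47
Compound 2 `COc1ccc(F)cc1CNCCCNc1ccnc2cc(Cc3ccccc3)ccc12`: 9.47

In a physicochemical assay for acid dissociation, compound 1 gives 9.47, and in this assay compound 2 gives 9.47. For the measured compounds named here, the two values sit level at the digits printed, and the only measured step, no change at the digits printed from compound 1 to compound 2 (within the scatter), falls within the scatter; that step swaps the group on a saturated chain carbon bound to an amine nitrogen.

Compound 3 `COc1ccc(F)cc1CNCCCNc1ccnc2cc(-c3ccc(C(F)(F)F)cc3)ccc12` is not yet measured in this assay. It differs from compound 2 in one place: 4-(trifluoromethyl)phenyl in place of benzyl on an aromatic carbon. This change sits on the aromatic part of the shared core, away from the chain carbons and amine nitrogens.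

Going by the values given here, no measured step touches this position, so there is nothing to show that altering the group on that aromatic carbon moves the reading. Among the compounds with values here, the one step that exists, no change at the digits printed from compound 1 to compound 2 (within the scatter), altered a group nearer to the amines and left the value unchanged within the scatter. On that footing the step of a number 0.07 log units lower from compound 2 to compound 3 (within the scatter) is expected to stay within the scatter. Compound 3 is therefore estimated to give 9.4, within a range from 9.05 to 9.75.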

Compound 3, acid dissociation constant: 9.47
Compound 3: middle estimate off by 0.07 log units, on the low side; measured number inside the range.
By their numbers in this assay, from the lowest: compounds 1, 2 and 3 (each within the scatter of the next).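

In this assay, for the compounds shown here, the reading shows no change at the digits printed from compound 2 to compound 3 (within the scatter) when 4-(trifluoromethyl)phenyl replaces benzyl on an aromatic carbon of the shared core, which gives the first direct look at this position. The entering group has 10 heavy atoms in place of 7, including 3 fluorine atoms, and swaps benzyl for a group with no carbon link to the core, yet this larger change in structure leaves the reading level within the scatter, just as the earlier swap on a saturated chain carbon did. Nothing available here offers an explanation for why the reading holds steady at this position.

Going by these compounds, both groups compared at this aromatic carbon have a six-membered aromatic ring of carbon only, no hydrogen-bond donors or acceptors and no net charge, so it remains open whether an amine or a carboxylic acid placed there would also leave the reading level. The compounds shown also leave open whether a longer chain in place of the one carrying the amine nitrogens would move it.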